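The source may hold more compounds than are shown below. What is called first, only, known or untested is meant among the compounds shown, and "the series" means these compounds.

Compound 2 `CCCCCOc1ccc(C(=O)c2ccc(Cn3ccnc3)cc2)cc1` stands highest of the two numbers in an assay on isolated protein for inhibition of Aromatase (Homo sapiens), read by fluorescence, with stated times of 10 min and 60 min (a higher number here means a weaker inhibitor, a lower number a stronger inhibitor), with 1300 nM; compound 1 `C#CCOc1ccc(C(=O)c2ccc(Cn3ccnc3)cc2)cc1` gives 210 nM. Compound 3 `CCC#CCOc1ccc(C(=O)c2ccc(Cn3ccnc3)cc2)cc1` carries but-1-yn-1-yl in place of butyl on a saturated chain carbon bound to an oxygen on an aromatic ring. Among the measured compounds shown here, the only measured step that bears on this change is a 6.2-fold higher number from compound 1 to compound 2 (0.79 log units; beyond the scatter), where a triple bond gave way to a saturated chain; the present change brings a triple bond back into a chain of the same length. A modest fall in the number is therefore expected, a 2.9-fold lower number from compound 2 to compound 3 (0.46 log units; beyond the scatter), smaller than that step. Compound 3 is estimated at 450 nM, within 150 nM to 1300 nM.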

Compound 3, half-maximal inhibitory concentration: 1430 nM
Beside the measured number, compound 3's estimate is 3.2-fold (0.50 log units) below it; the measured number lies above the stated range.
By their numbers in this assay, from the lowest: compound 1; then compounds 2 and 3 (each within the scatter of the next).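

In this assay, but-1-yn-1-yl in place of butyl gives a 1.1-fold higher number from compound 2 to compound 3 (0.04 log units; within the scatter), so on a saturated chain carbon bound to an oxygen on an aromatic ring, the triple bond does not separate these two chains of equal length. Ethyl in place of hydrogen on a triple-bonded carbon gives a 6.8-fold higher number from compound 1 to compound 3 (0.83 log units; beyond the scatter), so among these compounds the gap follows the added ethyl, with the triple bond kept. Nothing available gives a cause for either step.

Open, from the compounds shown here alone, is how the number moves with a methyl on the triple-bonded carbon. Also open, going by these compounds, is whether a longer chain ending in an amine or a carboxylic acid stays close to compound 1 or compound 3.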